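Sulfonyl aryl variation on a shared core: from compound 3 to 4

This account rests on a few compounds, and the source may have more. Where it says the series, first, only, none or still open, it means among the compounds named here.

Measured compounds:
compound 1 `Cc1ccc(S(=O)(=O)c2cnc3cc(F)ccc3c2N2CCC(C)CC2)cc1C` — 90%
compound 2 `CC1CCN(c2c(S(=O)(=O)c3ccc(Cl)c(Cl)c3)cnc3cc(F)ccc23)CC1` — 94%
compound 3 `CC1CCN(c2c(S(=O)(=O)c3ccc(C#N)cc3)cnc3cc(F)ccc23)CC1` — 83%

In an assay on isolated protein for displacement of a labelled ligand from metabotropic glutamate receptor 5 (Homo sapiens), with a stated time of 60 min, tested at 1 uM (on this read-out lower numbers stand for less inhibition and higher numbers for more inhibition at the one concentration tested (going by the name of the read-out)), compound 3 gives 83%, the lowest of the three numbers. Its nearest neighbour is compound 1, a step of a number 7 percentage points lower from compound 1 to compound 3 (within the scatter), and its furthest is compound 2, a step of a number 11 percentage points lower from compound 2 to compound 3 (beyond the scatter). The three compounds share one core and differ only in the aryl group on the sulfonyl sulfur.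

Compound 4 `COc1cccc(S(=O)(=O)c2cnc3cc(F)ccc3c2N2CCC(C)CC2)c1` is the next member of this set. The change from compound 3 is 3-methoxyphenyl in place of 4-cyanophenyl on a sulfonyl sulfur.

Which measured steps bear on this? All three steps swap one aryl group for another on the same sulfonyl sulfur: a number 4 percentage points higher from compound 1 to compound 2 (within the scatter), a number 7 percentage points lower from compound 1 to compound 3 (within the scatter) and a number 11 percentage points lower from compound 2 to compound 3 (beyond the scatter). Among the measured compounds shown here, none of them involves a methoxy-bearing ring, so the new group has no direct precedent here. The steps that exist are small, and the two rings that are not the 4-cyanophenyl sit somewhat higher than compound 3. A move back upward, of about the size seen between compound 2 and compound 3, is therefore expected for compound 4, though a result within the scatter of compound 3 is quite possible.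

Compound 4 is estimated at 87%, with a range from 72% to 96%, which would mean a step of a number 4 percentage points higher from compound 3 to compound 4 (within the scatter).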

Compound 4, a percentage reported as inhibition, at one concentration (the size of the read-out at that concentration, not a potency): 90%
Compound 4: middle estimate off by 3 percentage points, on the low side; the range from low to high includes it.
By their numbers in this assay, from the lowest: compounds 3, 1, 4 and 2 (each within the scatter of the next, the first and the last beyond it).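

In this assay, the exchange of 4-cyanophenyl for 3-methoxyphenyl on the sulfonyl sulfur gives a number 7 percentage points higher from compound 3 to compound 4 (within the scatter), so this swap cannot be separated from repeat variation, and the nitrile-bearing ring is not shown to differ from the methoxy-bearing one. Compound 4 is also not separated from the two disubstituted rings, with a number 4 percentage points lower from compound 2 to compound 4 (within the scatter) and no change at the digits printed from compound 1 to compound 4 (within the scatter), which means that the two chlorines or two methyl groups of those rings are not needed to stay in this range, and the step from compound 2 to compound 3 remains the only one beyond the scatter in the set of four. No measurement here explains these small steps or their direction.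

The four aryl groups all give high numbers at a single concentration, so the compounds shown do not tell whether they would differ in potency across a full concentration range. They also leave open how the sulfonyl sulfur position would respond to a ring carrying a carboxylic acid or an amine, or to a pyridine in place of the substituted phenyl ring.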